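Pyrazoline amide series: acyl variation at the ring nitrogen

This account rests on a few compounds, and the source may have more. Where it says the series, first, only, none or still open, it means among the compounds named here.

Compound 1 `CN1CCN(c2ccc(C3=NN(C(=O)c4ccc(F)cc4)C(c4ccc(N(C)C)cc4)C3)cc2)CC1` gives 32.2% in a functional assay on NCI-H1975 cells (Homo sapiens) for inhibition, read by sulforhodamine B assay, tested at 10 uM; a higher number here means more inhibition at the concentration tested (going by the name of the read-out), a lower number less inhibition. Among the measured compounds shown here, compound 2 `CN(C)c1ccc(C2CC(c3ccc(-n4cncn4)cc3)=NN2C(=O)c2ccc(F)cc2)cc1` gives -1.1% in this assay, the one measured step being a number 33.3 percentage points lower from compound 1 to compound 2 (beyond the scatter). Compound 3 `COC(=O)CC(=O)N1N=C(c2ccc(-n3ccnc3)cc2)CC1c1ccc(N(C)C)cc1` gives -0.1% in this assay, second highest of the three values, within the scatter of compound 2 and well below compound 1.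

Compound 4 `CN(C)c1ccc(C2CC(c3ccc(-n4ccnc4)cc3)=NN2C(=O)c2ccc(F)cc2)cc1` differs from compound 3 at the carbonyl carbon: 4-fluorophenyl in place of (methoxycarbonyl)methyl on a carbonyl carbon. For the measured compounds named here, no measured step covers this exchange; the only step available, from compound 1 to compound 2, changes a different group. Compound 2, which shares the (4-fluorophenyl)carbonyl group with compound 4, is near the bottom of the series, so no step beyond the scatter is expected, with a number 5.1 percentage points higher from compound 3 to compound 4 (within the scatter). Compound 4 is therefore estimated at 5%, ranging from -15% to 25%.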

Compound 4, a percentage reported as inhibition, at one concentration (the size of the read-out at that concentration, not a potency): -3.5%
Beside the measured number, compound 4's estimate is 8.5 percentage points above it; the measured number falls inside the stated range.
By their numbers in this assay, from the lowest: compounds 4, 2 and 3 (each within the scatter of the next); then compound 1.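

In this assay the exchange on the carbonyl carbon gives a number 3.4 percentage points lower from compound 3 to compound 4 (within the scatter) and so separates neither acyl group, though both compounds read close to zero, where a change at this position could go unseen. On the aromatic carbon, a number 2.4 percentage points lower from compound 2 to compound 4 (within the scatter) leaves 1H-imidazol-1-yl and 1H-1,2,4-triazol-1-yl indistinguishable, while a number 35.7 percentage points lower from compound 1 to compound 4 (beyond the scatter) sets 4-methylpiperazin-1-yl apart from both. Nothing at hand bears on the cause of these steps.

Open: whether 4-methylpiperazin-1-yl keeps its reading with ((methoxycarbonyl)methyl)carbonyl in place of (4-fluorophenyl)carbonyl, and what a morpholine or an open-chain amine on that aromatic carbon would give.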